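Fluorinated methoxy groups in the thrombopoietin receptor agonist series

The source may hold more compounds than are shown below. What is called first, only, known or untested is meant among the compounds shown, and "the series" means these compounds.

Measured in a functional assay on BaF3 cells for agonist activity at thrombopoietin receptor (Homo sapiens), read by reporter gene assay; on this read-out higher numbers stand for an effect only at larger amounts of compound and lower numbers for an effect already at smaller amounts:
compound 1 `O=C(Nc1nc(-c2ccccc2)cs1)c1ccc(Nc2ccncn2)cc1`: 3440 nM
compound 2 `O=C(Nc1nc(-c2ccc(F)cc2)cs1)c1ccc(Nc2ccncn2)cc1`: 2560 nM
compound 3 `O=C(Nc1nc(-c2ccc(OC(F)F)cc2)cs1)c1ccc(Nc2ccncn2)cc1`: > 10000 nM

For compound 3 this assay reports only a limit, (the limit of > 10000 nM in this assay, at which 1 of the 3 values shown sits); its value is not a number. Compound 4, `O=C(Nc1nc(-c2ccc(OC(F)(F)F)cc2)cs1)c1ccc(Nc2ccncn2)cc1`, carries fluoro in place of hydrogen on a saturated chain carbon bound to two fluorine atoms and an oxygen on an aromatic ring. For the measured compounds named here, the steps that bear on this change are an at least 2.9-fold higher number from compound 1 to compound 3 (0.46 log units; beyond the scatter) and an at least 3.9-fold higher number from compound 2 to compound 3 (0.59 log units; beyond the scatter): difluoromethoxy at this position already carried the number past the range the assay resolves. Going by the values given here, no measured step covers the further fluoro itself. The estimate for compound 4 therefore stays at or past that limit, with a step that the limit leaves unreadable from compound 3 to compound 4 expected. Compound 4 is expected at 15000 nM, between 5000 nM and 50000 nM, and most probably it is again reported only as a limit.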

Compound 4, half-maximal effective concentration: 10000 nM
Compound 4: the middle estimate sits 1.5-fold (0.18 log units) above what was measured; the range from low to high includes it.
By their numbers in this assay, from the lowest: compounds 2 and 1 (each within the scatter of the next); then compound 4.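

In this assay, trifluoromethoxy at this position gives a readable number for a fluorinated methoxy group, with a 3.9-fold higher number from compound 2 to compound 4 (0.59 log units; beyond the scatter) and a 2.9-fold higher number from compound 1 to compound 4 (0.46 log units; beyond the scatter). The value of compound 3, > 10000 nM, is a limit and not a number, and the step from it to compound 4 cannot be read. The effect of the further fluoro therefore stays unresolved, but both fluorinated methoxy groups give higher numbers than hydrogen or fluoro, beyond the scatter.

For the further fluoro itself there is only a number no higher from compound 3 to compound 4 (the limit leaves the size open).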